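The source may report more compounds than this note shows. Statements on the series, on what has been measured and on what is new or still open speak of the compounds shown alone.

Among the compounds with values here, in a functional assay on the whole organism with Mus musculus as the target, in the rotarod test (a lower number here means that less compound is needed, a higher number that more compound is needed for the effect), compound 1 `COc1cc2c(cc1OC)C(c1cccc(N)c1)=NN=C(S)C2` gives 76.7 umol/kg and compound 2 `COc1cc2c(cc1OC)C(c1ccc(Br)cc1)=NN=C(S)C2` gives 73 umol/kg, so compound 2 stands level with the only other measured compound. Compound 3 `COc1cc2c(cc1OC)C(c1ccc(Cl)cc1)=NN=C(S)C2` differs at one place: chloro in place of bromo on an aromatic carbon, para to a large group. Within the data shown here, no measured step exchanges bromo for chloro. The nearest evidence is the change of 3-aminophenyl to 4-bromophenyl, which gave a 1.1-fold lower number from compound 1 to compound 2 (0.02 log units; within the scatter). The expected step is a 1.0-fold higher number from compound 2 to compound 3 (0.01 log units; within the scatter), with no shift beyond the scatter in this assay. Compound 3 is estimated at 75 umol/kg, within an expected range of 40 umol/kg to 140 umol/kg.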

Compound 3, dose for half-maximal effect: 193 umol/kg
Compound 3: middle estimate off by 2.6-fold (0.41 log units), on the low side, and the stated range ends below it.
By their numbers in this assay, from the lowest: compounds 2 and 1 (each within the scatter of the next); then compound 3.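

In this assay chloro in place of bromo gives a 2.6-fold higher number from compound 2 to compound 3 (0.42 log units; beyond the scatter) and so shows that this aromatic carbon is sensitive to the exchange of one halogen for another. The change to 4-chlorophenyl also gives a 2.5-fold higher number from compound 1 to compound 3 (0.40 log units; beyond the scatter) while 4-bromophenyl and 3-aminophenyl stand level, so the aryl group can matter after all. Nothing available bears on the reason for this gap. From the compounds shown here alone, whether fluoro or methoxy on the same carbon would stand with bromo or with chloro remains open. Going by these compounds, the response to an amine at that carbon also remains open.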